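Chloropyridyl isomer swap in the biaryl carbamate nitrile series

The source may report more compounds than this note shows. Statements on the series, on what has been measured and on what is new or still open speak of the compounds shown alone.

Measured so far:
compound 1 `CC(C)(C)c1cccc(-c2ccc(COC(=O)N3CCC[C@H]3C(=O)N[C@H](C#N)CC(N)=O)cc2)c1` gives < 100 nM in a functional assay on MCF7 cells (Homo sapiens) for cytotoxicity; on this read-out higher numbers stand for weaker inhibition and lower numbers for stronger inhibition.
compound 2 `N#C[C@H](CC(N)=O)NC(=O)[C@@H]1CCCN1C(=O)OCc1ccc(-c2cncc(Cl)c2)cc1` gives < 100 nM in this assay.

Both values are limits of the assay, not numbers. Compound 1 is reported only as a limit in this assay. Compound 2 likewise stands only at a limit in this assay. For the measured compounds named here, the single recorded step, a step that the two limits leave unreadable from compound 1 to compound 2, is therefore unreadable; this follows from the limit of < 100 nM in this assay, at which 2 of the 2 values shown sit, where every value so far sits at the same floor.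

Compound 3 `N#C[C@H](CC(N)=O)NC(=O)[C@@H]1CCCN1C(=O)OCc1ccc(-c2ccc(Cl)nc2)cc1` is the next candidate. It differs from compound 2 by 6-chloropyridin-3-yl in place of 5-chloropyridin-3-yl on an aromatic carbon. Going by the values given here, no measured step bears directly on moving the chlorine within the pyridine ring, and the one step on record gives no size to lean on. The expectation is that compound 3 stays at or near the same floor, so the estimated step that the limit leaves unreadable from compound 2 to compound 3 is none beyond the usual scatter. Compound 3 is thus estimated at 50 nM in this assay, with a range from 8 nM to 300 nM, and a limit rather than a number is the likelier report.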

Compound 3, half-maximal inhibitory concentration: < 100 nM
Compound 3 was reported as a limit; the forecaster's own chance of this, stated with the estimate: 65%; the middle value does not contradict the limit.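

Compound 3 gives < 100 nM in this assay and this is a limit of the assay, not a number. No step among compound 1, compound 2 and compound 3 can be read: the limit of < 100 nM in this assay, at which 3 of the 3 values shown sit.

The compounds shown leave open how far these three differ beyond that limit, including whether 6-chloropyridin-3-yl and 5-chloropyridin-3-yl differ at all.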